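Working notes on a three-compound series and compound 4

The source may report more compounds than this note shows. Statements on the series, on what has been measured and on what is new or still open speak of the compounds shown alone.

Measured so far:
compound 1, `Cc1ccc(N2CCN(c3ccc(C(=O)/C=C/c4ccccc4)cc3)CC2)c(C)c1`: 15%
compound 2, `O=C(/C=C/c1ccccc1)c1ccc(N2CCN(c3cccc(Cl)c3Cl)CC2)cc1`: 30.7%
compound 3, `Cc1ccc(S(=O)(=O)N2CCN(c3ccc(C(=O)/C=C/c4ccccc4)cc3)CC2)cc1`: 30.8%

In a functional assay on the whole organism (strain Kunming) for inhibition, with Mus musculus as the target, with a stated time of 1 h, at a dose of 40 mg/kg by the oral route (on this read-out higher numbers stand for more inhibition at the one dose given (going by the name of the read-out) and lower numbers for less inhibition), compound 3 carries the highest of the three numbers, though its lead over compound 2 is slight: the step of a number 0.1 percentage points higher from compound 2 to compound 3 (within the scatter) lies within the scatter, so no order between compound 2 and compound 3 can be claimed. Against compound 1 the picture is clearer, with a number 15.8 percentage points higher from compound 1 to compound 3 (beyond the scatter) and, for the parallel change, a number 15.7 percentage points higher from compound 1 to compound 2 (beyond the scatter) both beyond the scatter.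

Compound 4, `O=C(/C=C/c1ccccc1)c1ccc(N2CCN(S(=O)(=O)c3ccc(OC(F)(F)F)cc3)CC2)cc1`, differs from compound 3 as follows: trifluoromethoxy in place of methyl on an aromatic carbon. Every measured step in this series changes the group on the amine nitrogen in the ring; none touches the substituent on the (4-methylphenyl)sulfonyl group. Among the compounds with values here, no measured step therefore bears on this change, and the expectation for compound 4 rests only on the value of compound 3.

For compound 4 the expected step of a number 0.2 percentage points higher from compound 3 to compound 4 (within the scatter) is not beyond the scatter. Compound 4 is thus estimated at 31%, with a range from 15% to 47%.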

Compound 4, a percentage reported as inhibition, in the whole organism at one dose (the size of the read-out at that dose, not a potency): 47.4%
Compound 4: middle estimate off by 16.4 percentage points, on the low side, and the stated range ends below it.
By their numbers in this assay, from the lowest: compound 1; then compounds 2 and 3 (each within the scatter of the next); then compound 4.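

In this assay, trifluoromethoxy in place of methyl on an aromatic carbon, para to a large group, gives a number 16.6 percentage points higher from compound 3 to compound 4 (beyond the scatter) and ranks compound 4 first among the compounds in the series. Within the data shown here, this is the first sign that the 4-methylphenyl end of the sulfonyl group affects the read-out: a substituent change at this place gives a modest step, just as the change on the amine nitrogen does in a number 15.8 percentage points higher from compound 1 to compound 3 (beyond the scatter) and not merely the swap of the whole nitrogen group. Nothing shown accounts for the step.

Only methyl and trifluoromethoxy are shown at this place, so it remains open whether a methoxy or a trifluoromethyl group would give a step of similar size. Also open, on these data alone, is how an amine or a carboxylic acid at this place would read out.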